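Working notes: carbamoylpyridinyl variant of compound 1

A few compounds are considered here, and "the series" means these few. Any claim that something is new, unique, unknown or untested is made for them only; others in the source may bear on it.

Measured so far in an assay (Rattus norvegicus) for inhibition of Fatty-acid amide hydrolase 1 (Homo sapiens); a higher number here means a weaker inhibitor, a lower number a stronger inhibitor:
compound 1, `O=C(O)c1ccc(-c2cnc(C(=O)CCCCCCc3ccccc3)o2)cc1`, gives 60 nM
compound 2, `NS(=O)(=O)c1ccc(-c2cnc(C(=O)CCCCCCc3ccccc3)o2)cc1`, gives 10 nM

Compound 1 has the highest number of the two in this assay; its nearest neighbour is compound 2, reached by the step of a 6.0-fold lower number from compound 1 to compound 2 (0.78 log units; beyond the scatter), which exchanges the carboxy group for a sulfamoyl group on the shared core.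

Compound 3, `NC(=O)c1ccc(-c2cnc(C(=O)CCCCCCc3ccccc3)o2)nc1`, is not yet measured. It differs from compound 1 as follows: 5-carbamoylpyridin-2-yl in place of 4-carboxyphenyl on an aromatic carbon

Within the data shown here, no measured step covers this exchange directly. Among the measured compounds shown here, the only step at hand, a 6.0-fold lower number from compound 1 to compound 2 (0.78 log units; beyond the scatter), shows that replacing the carboxy group with another uncharged group carrying one hydrogen-bond donor lowered the number by a modest margin. The carbamoyl group of compound 3 also carries one hydrogen-bond donor and no net charge, but the ring it sits on is a pyridine rather than a benzene, and nothing measured speaks to that change. A step in the same direction as for compound 2, but smaller and with wide uncertainty, is therefore expected: a 2.4-fold lower number from compound 1 to compound 3 (0.38 log units; beyond the scatter).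

For compound 3 the estimate in this assay is 25 nM, with a range from 7 nM to 90 nM.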

Compound 3, inhibition constant: 1.2 nM
Compound 3: the middle estimate sits 21-fold (1.32 log units) above what was measured, and the stated range ends above it.
By their numbers in this assay, from the lowest: compound 3; then compound 2; then compound 1.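

On the aromatic carbon next to the ring oxygen of the shared core, the exchange of 4-carboxyphenyl for 5-carbamoylpyridin-2-yl gives a 50-fold lower number from compound 1 to compound 3 (1.70 log units; beyond the scatter) in this assay and so goes well past the step of a 6.0-fold lower number from compound 1 to compound 2 (0.78 log units; beyond the scatter) seen with the sulfamoyl group. The number at this position can therefore fall much further than the first pair showed, with compound 2 at 10 nM and compound 3 at 1.2 nM on the same core. The exchange alters the ring and the group on it together, and nothing at hand bears on why the number falls.

As far as these compounds go, how the step divides between the ring nitrogen and the carbamoyl group remains open: a 4-carbamoylphenyl group and a 5-carboxypyridin-2-yl group on this carbon would separate the two contributions. Also open is whether the low number of compound 3 survives a shorter chain between the carbonyl and the phenyl ring, since all three compounds shown carry the same chain.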